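The compounds below may be only part of what the source reports. "The series", "measured", "known", "first", "only" and "open" are said of these compounds alone.

Measured compounds:
compound 1 `O=C(NC(=S)Nc1cccc(-c2nc3ccccc3[nH]2)c1)c1ccccc1`: > 10000 nM
compound 2 `CCOc1ccc(C(=O)NC(=S)Nc2cccc(-c3nc4ccccc4[nH]3)c2)cc1OCC`: "not determined" (no result reported)
compound 3 `CCOc1ccc(C(=O)NC(=S)Nc2cc(-c3nc4ccccc4[nH]3)ccc2C)cc1OCC`: "not determined" (no result reported)

In a functional assay on MDA-MB-231 cells (Homo sapiens) for inhibition, read by colorimetric assay and crystal violet staining, with a stated time of 72 h (on this read-out lower numbers stand for stronger inhibition and higher numbers for weaker inhibition), compound 1 gives > 10000 nM, which is a limit of the assay and not a number. Compound 2 returns "not determined" (no result reported) in this assay, and compound 3 likewise returns "not determined" (no result reported); neither contributes a number to the series. Compound 1 therefore stands at the limit of > 10000 nM in this assay, at which 1 of the 3 values shown sits, with no other entry to set it against. For the measured compounds named here, no step between measured compounds is available, so nothing shows how a change at the carbonyl carbon moves the read-out.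

Compound 4 `O=C(NC(=S)Nc1cccc(-c2nc3ccccc3[nH]2)c1)c1ccc2c(c1)OCCO2` is the next compound to be measured in this assay. Against compound 1 the difference is 2,3-dihydro-1,4-benzodioxin-6-yl in place of phenyl on a carbonyl carbon. Compound 2 and compound 3 have no result, so the expectation for compound 4 rests on compound 1 alone. The step from compound 1 to compound 4 is expected to be a step that the limit leaves unreadable from compound 1 to compound 4, that is, no movement beyond the scatter, with a good chance that only a limit is reported again. For compound 4 the estimate is 12000 nM, with a range from 3000 nM to 50000 nM.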

Compound 4, half-maximal inhibitory concentration: 500 nM
Beside the measured number, compound 4's estimate is 24-fold (1.38 log units) above it; the whole stated range lies above it.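

In this assay, for the compounds shown here, the group on the carbonyl carbon proves able to move the read-out, something no earlier compound could show: 2,3-dihydro-1,4-benzodioxin-6-yl in place of phenyl gives an at least 20-fold lower number from compound 1 to compound 4 (1.30 log units; beyond the scatter). Going by these compounds alone, with 500 nM, compound 4 also provides the first single number, so this position now has a measured reference point against which further changes to the group can be read. The step has a lower bound only, and its full size stays unknown, because the value for compound 1 is a limit of the assay and not a number: the limit of > 10000 nM in this assay, at which 1 of the 4 values shown sits.

The compounds shown do not separate the contribution of the ring oxygens from that of the closed non-aromatic ring, and the two ethoxy groups of compound 2 and compound 3 cannot help, since neither compound has a result. On these data alone, it also remains open how a single methoxy group, an amine or a carboxylic acid on the phenyl would compare with the 2,3-dihydro-1,4-benzodioxin-6-yl group at this position.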